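The compounds below may be only part of what the source reports. "The series", "measured", "known", "first", "only" and "open" are said of these compounds alone.

Measured in a functional assay on COR-L23 cells (Homo sapiens) for antiproliferative activity, read by CellTiter-Glo, with a stated time of 72 h; on this read-out lower numbers stand for stronger inhibition and higher numbers for weaker inhibition:
- compound 1 `Nc1ccc(CNC(=O)Nc2ccc(CN3C(=O)c4ccccc4C3=O)cc2)cn1`: 3.1 nM
- compound 2 `O=C(Nc1ccc(CN2Cc3ccccc3C2=O)cc1)N1CC(c2cccnc2)C1`: 9.9 nM
- compound 3 `C[C@@H](c1ccc(NC(=O)N2CC(c3cccnc3)C2)cc1)N1Cc2ccccc2C1=O`: 8 nM

Compound 3, at 8 nM, lies within the scatter of compound 2 and beyond the scatter from compound 1, which has the lower number.

Next in the series is compound 4 `C[C@H](NC(=O)C1CCOCC1)c1ccc(NC(=O)N2CC(c3cccnc3)C2)cc1`. The change is a group of 9 heavy atoms (6 carbon, 1 nitrogen, 2 oxygen; one six-membered non-aromatic ring with 1 hetero atom) in place of a group of 10 heavy atoms (8 carbon, 1 nitrogen, 1 oxygen; one five-membered non-aromatic ring with 1 hetero atom, one six-membered aromatic ring of carbon only), on a saturated chain carbon bound to an aromatic carbon and a saturated chain carbon. The entering group is ((oxan-4-yl)carbonyl)amino, and the leaving group carries the six-membered aromatic ring of carbon only.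

Among the compounds with values here, only one measured step bears on this, and only indirectly: a 1.2-fold lower number from compound 2 to compound 3 (0.09 log units; within the scatter). That step is methyl in place of hydrogen, so it shows that the methyl made no difference beyond the scatter, but it does not test the group now being exchanged. Within the data shown here, no measured step covers this exchange, so the size of the change remains poorly defined.

All three numbers in this assay lie close together, with compound 1 at 3.1 nM and compound 2 at 9.9 nM, but these few compounds offer only weak support. A moderate move towards a higher number is expected, with a wide margin, and the expected step is a 2.5-fold higher number from compound 3 to compound 4 (0.40 log units; beyond the scatter). The estimate for compound 4 is 20 nM, with an expected range from 5 nM to 80 nM.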

Compound 4, half-maximal inhibitory concentration: 58 nM
Beside the measured number, compound 4's estimate is 2.9-fold (0.46 log units) below it; low and high end bracket the measured number.
By their numbers in this assay, from the lowest: compound 1; then compounds 3 and 2 (each within the scatter of the next); then compound 4.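

On the saturated chain carbon bound to an aromatic carbon and a saturated chain carbon, replacing the group that carries the six-membered aromatic ring of carbon only with ((oxan-4-yl)carbonyl)amino gives a 7.3-fold higher number from compound 3 to compound 4 (0.86 log units; beyond the scatter) in this assay. This position therefore responds to the group it carries, a point that the earlier step at this carbon, a 1.2-fold lower number from compound 2 to compound 3 (0.09 log units; within the scatter), could not show, since a methyl in place of hydrogen stayed within the scatter. The exchange alters several features at once, removing the aromatic ring and bringing in a six-membered non-aromatic ring with 1 hetero atom and 1 hydrogen-bond donor, and nothing shown gives a reason for the size of this step.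

From the compounds shown here alone, it remains open whether the step follows the oxan-4-yl ring, the amide link of the entering group or the departure of the aromatic ring. Also open, going by these compounds, is how a benzoylamino group, a plain amine or a carboxylic acid on this same carbon would read in this assay, which could help separate these features.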